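This account rests on a few compounds, and the source may have more. Where it says the series, first, only, none or still open, it means among the compounds named here.

Compound 3 `CC(C)n1cc(-c2ccnc3[nH]c(C4CCN(CC(=O)N(C)C)CC4)cc23)ccc1=O` gives 2.3 uL/min in an ADME assay on cells (Hepatocyte, Rattus norvegicus) for metabolic stability; on this read-out higher numbers stand for fast clearance and lower numbers for slow clearance. Against the other two members of the series it stands thus: compound 1 `CC(=O)N1CCC(c2cc3c(-c4ccc(=O)n(C(C)C)c4)ccnc3[nH]2)CC1` gives 2.8 uL/min, and the step of a 1.2-fold lower number from compound 1 to compound 3 (0.09 log units; within the scatter) is within the scatter, so the two numbers are not distinguishable; compound 2 `CC(C)n1cc(-c2ccnc3[nH]c(C4CCN(CC(=O)N5CCCC5)CC4)cc23)ccc1=O` gives 5.4 uL/min, and the step of a 2.3-fold lower number from compound 2 to compound 3 (0.37 log units; beyond the scatter) does separate them. The remaining pair, a 1.9-fold higher number from compound 1 to compound 2 (0.29 log units; within the scatter), does not.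

Compound 4 `CC(C)n1cc(-c2ccnc3[nH]c(C4CCN(Cc5cccs5)CC4)cc23)ccc1=O` differs from compound 3 in one place: thiophen-2-yl in place of dimethylcarbamoyl on a saturated chain carbon bound to an amine nitrogen in a ring. None of the three measured steps bears directly on this change; all of them compare one amide carbonyl group with another on the same amine nitrogen in a ring, and none replaces that carbonyl with an aromatic ring. For the measured compounds named here, the only guidance is the narrow spread of the three numbers so far. The step from compound 3 to compound 4 is therefore expected to be small, a 1.7-fold higher number from compound 3 to compound 4 (0.24 log units; within the scatter), with wide uncertainty in both directions. Compound 4 is estimated at 4 uL/min, in the range 1.5 uL/min to 11 uL/min.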

Compound 4, intrinsic clearance in a liver preparation (reported as CLH), per the amount of preparation that the assay uses: 43 uL/min
Compound 4: middle estimate off by 11-fold (1.03 log units), on the low side; measured number outside the range, above it.
By their numbers in this assay, from the lowest: compounds 3, 1 and 2 (each within the scatter of the next, the first and the last beyond it); then compound 4.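

On an amine nitrogen in a ring, the acetyl and carbamoylmethyl groups gave only a narrow spread in this assay, but (thiophen-2-yl)methyl lies clear of all three: a 19-fold higher number from compound 3 to compound 4 (1.27 log units; beyond the scatter) as the largest step, a 15-fold higher number from compound 1 to compound 4 (1.19 log units; beyond the scatter) close to it and an 8.0-fold higher number from compound 2 to compound 4 (0.90 log units; beyond the scatter) as the smallest. This position can therefore move the read-out far more than the swaps among carbonyl-bearing groups showed, and in these four compounds the only substituent without a carbonyl has the highest number. Nothing supplied explains the jump.

Still open, on these data alone, is whether the high number goes with the thiophene ring itself or with any group lacking the carbonyl, as one compound cannot separate the two. A benzyl group, a pyridinylmethyl group or a plain alkyl chain on the same nitrogen would bear on this.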